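Aryl variation at the chromone two-position: notes on the series

The source may report more compounds than this note shows. Statements on the series, on what has been measured and on what is new or still open speak of the compounds shown alone.

Measured so far:
compound 1 `COc1c(OCCCCN2CCN(C)CC2)cc(O)c2c(=O)cc(-c3ccc(C)cc3)oc12`: 3810 nM
compound 2 `COc1c(OCCCCN2CCN(C)CC2)cc(O)c2c(=O)cc(-c3ccc([N+](=O)[O-])cc3)oc12`: 3210 nM

Both numbers come from a functional assay on A549 cells (Homo sapiens) for cytotoxicity, read by MTT assay, with a stated time of 72 h; a lower number here means a stronger inhibitor, a higher number a weaker inhibitor. In this assay compound 2 gives the lower of the two values, but the step of a 1.2-fold lower number from compound 1 to compound 2 (0.07 log units; within the scatter) is within the scatter, so the two compounds cannot be ordered.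

Compound 3 `COc1c(OCCCCN2CCN(C)CC2)cc(O)c2c(=O)cc(-c3ccc(F)cc3Br)oc12` is the next member and has not been measured in this assay. It differs from compound 2 in one place: 2-bromo-4-fluorophenyl in place of 4-nitrophenyl on an aromatic carbon. Going by the values given here, the only measured step that bears on this change is the one on the same aromatic ring, a 1.2-fold lower number from compound 1 to compound 2 (0.07 log units; within the scatter), which did not move the number beyond the scatter. Among the compounds with values here, no measured step covers a halogenated ring or a ring carrying two substituents, so the expectation rests on that single step alone.

On this basis no step beyond the scatter is expected; the estimated step is a 1.1-fold higher number from compound 2 to compound 3 (0.04 log units; within the scatter). Compound 3 is therefore expected to give about 3500 nM in this assay, with a range from 1400 nM to 9000 nM.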

Compound 3, half-maximal inhibitory concentration: 2980 nM
Estimate against measurement, compound 3: 1.2-fold (0.07 log units) above; the range from low to high includes it.
By their numbers in this assay, from the lowest: compounds 3, 2 and 1 (each within the scatter of the next).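

Working notes on the step to compound 3. In this assay, the change from 4-nitrophenyl to 2-bromo-4-fluorophenyl (a 1.1-fold lower number from compound 2 to compound 3 (0.03 log units; within the scatter)) and the change from 4-methylphenyl to the same group (a 1.3-fold lower number from compound 1 to compound 3 (0.11 log units; within the scatter)) both stay within the scatter. This extends the earlier finding to a halogenated aryl group carrying two substituents, so the three aryl groups at this position next to the ring oxygen are not separated and compounds 1, 2 and 3 cannot be ordered. Nothing available accounts for how closely these values lie together.

Going by these compounds, it remains open whether an amine or a carboxylic acid on the aryl ring would move the number beyond the scatter. The compounds shown also leave open whether a longer chain in place of the one on the shared core would change the picture.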